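Adding a Third Methoxy Group to the Benzylamine Ring

The source may hold more compounds than are shown below. What is called first, only, known or untested is meant among the compounds shown, and "the series" means these compounds.

Of the compounds shown here, two of a shared core have been tested so far. Compound 1 `Nc1cc(N)c2nc(-c3ccccc3)c(NCc3ccc(Cl)c(Cl)c3)nc2c1` carries a 3,4-dichlorophenyl group on the saturated chain carbon bound to the ring nitrogen, and in a functional assay on M14 cells (Homo sapiens) for inhibition, read by sulforhodamine B assay, with a stated time of 48 h (on this read-out lower numbers stand for higher toxicity in this test and higher numbers for lower toxicity in this test), compound 1 gives 75900 nM. Compound 2 `COc1ccc(CNc2nc3cc(N)cc(N)c3nc2-c2ccccc2)cc1OC` carries a 3,4-dimethoxyphenyl group in the same place, and in this assay compound 2 gives 33900 nM. For the measured compounds named here, the only step measured is a 2.2-fold lower number from compound 1 to compound 2 (0.35 log units; beyond the scatter), so compound 2 stands at the lowest of the two numbers, with compound 1 as its only neighbour.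

Compound 3 `COc1cc(CNc2nc3cc(N)cc(N)c3nc2-c2ccccc2)cc(OC)c1OC` is the next candidate. It differs from compound 2 by methoxy in place of hydrogen on an aromatic carbon. Going by the values given here, only the step from compound 1 to compound 2 touches the same phenyl ring, and it was modest. A single further methoxy group on that ring is a smaller change than swapping two chlorines for two methoxy groups, so a small step, or none beyond the scatter, is expected in this assay, leaning toward a lower number. The expected step is a 1.4-fold lower number from compound 2 to compound 3 (0.13 log units; within the scatter). Compound 3 is therefore estimated at 25000 nM, within a range from 10000 nM to 60000 nM.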

Compound 3, concentration lethal to 50% of the cells: 34700 nM
For compound 3 the middle estimate is 1.4-fold (0.14 log units) below the measured one; the measured number falls inside the stated range.
By their numbers in this assay, from the lowest: compounds 2 and 3 (each within the scatter of the next); then compound 1.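

The methoxy group that enters on the aromatic carbon, ortho to a methoxy group and meta to a large group, gives a 1.0-fold higher number from compound 2 to compound 3 (0.01 log units; within the scatter) in this assay. The earlier step, a 2.2-fold lower number from compound 1 to compound 2 (0.35 log units; beyond the scatter), showed that exchanging the substituents on this phenyl ring could change the number beyond the scatter, whereas this one shows that a change on the same ring can also leave it within the scatter: with a methoxy group already on each neighbouring side of this carbon in the ring's pattern, the further methoxy group brings no readable difference in this test. No measurement at hand offers an explanation for why this addition leaves the number where it stands.

As far as these compounds go, what remains open is whether a different group on this same aromatic carbon, such as a hydroxyl, an amine or a longer ethoxy chain, would move the number beyond the scatter. From the compounds shown here alone, it is also open whether a single methoxy group on this ring, without the other two, would give a number close to those of compound 2 and compound 3.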